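Second chloro on the shared core: an expectation

A few compounds are considered here, and "the series" means these few. Any claim that something is new, unique, unknown or untested is made for them only; others in the source may bear on it.

Compound 1 `ClCc1cccc(Cn2cnc3ncnc(Cl)c32)c1`: 3540 nM
Compound 2 `ClCc1cccc(Cn2cnc3c(Cl)ncnc32)c1`: 5750 nM
Compound 3 `ClCc1ccccc1Cn1cnc2ncnc(Cl)c21`: 18600 nM

Three compounds were tested in a functional assay on SK-MEL-28 cells (Homo sapiens) for cytotoxicity, read by sulforhodamine B assay, with a stated time of 48 h; on this read-out lower numbers stand for stronger inhibition of growth and higher numbers for weaker inhibition of growth. Compound 1 gives 3540 nM, the lowest of the three numbers. Its nearest neighbour is compound 2, whose value of 5750 nM lies within the usual scatter of this assay, so the two cannot be told apart. The furthest is compound 3, which in this assay gives 18600 nM, a gap from compound 1 that lies beyond the scatter.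

Compound 4 `ClCc1cccc(Cn2cnc3nc(Cl)nc(Cl)c32)c1` has not yet been measured. It differs from compound 1 in one place: chloro in place of hydrogen on an aromatic carbon. Among the measured compounds shown here, no pair among the measured compounds shows this kind of change, so nothing in the present numbers tells how large its effect should be, or in which direction.

For the measured compounds named here, with no comparable step available, the account rests on compound 1 alone. The step from compound 1 to compound 4 in this assay is expected to be a 1.3-fold lower number from compound 1 to compound 4 (0.10 log units; within the scatter), that is, none beyond the scatter. Going by the values given here, compound 4 is therefore expected to give about 2800 nM in this assay, within a range from 800 nM to 9000 nM, the width of the range reflecting that no measured step guides the estimate.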

Compound 4, concentration for total growth inhibition: 400 nM
Estimate against measurement, compound 4: 7.0-fold (0.85 log units) above; the whole stated range lies above it.
By their numbers in this assay, from the lowest: compound 4; then compounds 1 and 2 (each within the scatter of the next); then compound 3.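

The carbon between two ring nitrogen atoms now proves able to move the number: in this assay, chloro in place of hydrogen there gives an 8.9-fold lower number from compound 1 to compound 4 (0.95 log units; beyond the scatter), a step beyond the scatter. Among the compounds shown here, compounds 1, 2 and 3 all carry hydrogen at this carbon, so they could not show that this position responds to substitution, and the new step is the first measured one between two compounds that differ in a single place. Nothing available bears on why the chloro has this effect, so the step stands as an observation without an explanation.

The compounds shown carry only hydrogen or chloro at this carbon, so it remains open whether an amine, a methoxy group or a methyl group there would give a step of similar size, or any step beyond the scatter. On these data alone, it also remains open whether the same chloro would give a comparable step on compound 2 or compound 3, where the chloromethyl group or the first chloro sits elsewhere.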